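The compounds below may be only part of what the source reports. "The series", "measured", "known", "first", "only" and "open" are said of these compounds alone.

Compound 1 `CCCN(CC#Cc1cc2ncnc(Nc3ccc(OCc4cccc(F)c4)c(Cl)c3)c2s1)CCC` was examined in an ADME assay on NIH3T3 cells (Mus musculus) for cytotoxicity; a lower number here means that less compound is tolerated, a higher number that more compound is tolerated. In this assay compound 1 gives > 50 uM, which is a limit of the assay and not a number. It stands at the limit of > 50 uM in this assay, at which 1 of the 2 values shown sits. Compound 2 `CC(C)(C)OC(=O)N1CCN(CC#Cc2cc3ncnc(Nc4ccc(OCc5cccc(F)c5)c(Cl)c4)c3s2)CC1` was also measured, and in this assay compound 2 gives 47 uM. Compound 3 `CC(C)(C)OC(=O)N1CCC[C@H]1C#Cc1cc2ncnc(Nc3ccc(OCc4cccc(F)c4)c(Cl)c3)c2s1` differs from compound 1 by 1-(tert-butoxycarbonyl)pyrrolidin-2-yl in place of (dipropylamino)methyl on a triple-bonded carbon. Going by the values given here, no measured step covers this change, so no step beyond the scatter is expected in either direction. Compound 3 is therefore expected to give 50 uM in this assay, with a range from 30 uM to 80 uM. The expected step is a number no higher from compound 1 to compound 3 (the limit leaves the size open).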

Compound 3, half-maximal toxic concentration: > 100 uM
Compound 3: only a limit was reported; the forecaster's own chance of this, stated with the estimate: 50%; middle value at least 2.0-fold (0.30 log units) from the limit.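

In this assay, going by these compounds alone, compound 1 and compound 3 are both reported only as limits of the assay, so no step between them can be read. The compounds shown leave open what 1-(tert-butoxycarbonyl)pyrrolidin-2-yl in place of (dipropylamino)methyl does to the tolerated concentration.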